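The compounds below may be only part of what the source reports. "The series", "measured", "known", "first", "only" and "open" are said of these compounds alone.

Compound 2 `Cc1ccc(-[n+]2noc([O-])c2CN2CCNCC2)cc1` gives the highest of the two numbers in an ADME assay on HEL cells (Homo sapiens) for cytotoxicity (a higher number here means that more compound is tolerated, a lower number that less compound is tolerated), where compound 2 gives 100 ug/mL. Compound 1 `Cc1ccc(-[n+]2noc([O-])c2CN2CCN(c3cccc(Cl)c3Cl)CC2)cc1` in this assay gives 20 ug/mL. Among the measured compounds shown here, the only measured step, a 5.0-fold higher number from compound 1 to compound 2 (0.70 log units; beyond the scatter), is the one that bears here. Compound 3 `Cc1ccc(-[n+]2noc([O-])c2CN2CCN(c3ccccc3)CC2)cc1` carries phenyl in place of hydrogen on an amine nitrogen in a ring. This runs in the opposite sense to that measured step, though with a smaller entering group, so a lower number is expected for compound 3, of a size at or somewhat below that step. For compound 3 the estimate is 30 ug/mL, in the range 12 ug/mL to 70 ug/mL, an expected step of a 3.3-fold lower number from compound 2 to compound 3 (0.52 log units; beyond the scatter).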

Compound 3, minimum cytotoxic concentration: 100 ug/mL
Beside the measured number, compound 3's estimate is 3.3-fold (0.52 log units) below it, and the stated range ends below it.
By their numbers in this assay, from the lowest: compound 1; then compounds 2 and 3 (each within the scatter of the next).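

In this assay, phenyl on the amine nitrogen in the ring reads the same as hydrogen, with no change at the digits printed from compound 2 to compound 3 (within the scatter), so an aromatic ring at this position does not by itself bring the lower number seen for compound 1. The gap appears only with the 2,3-dichlorophenyl group, with a 5.0-fold higher number from compound 1 to compound 3 (0.70 log units; beyond the scatter). Nothing available gives a reason for this gap.

Going by these compounds, whether one chlorine on the phenyl is enough remains open, and so does which of the two chlorines matters. A methoxy group or a carboxylic acid on that phenyl is also untested among the compounds shown.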